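The source may report more compounds than this note shows. Statements on the series, on what has been measured and on what is new or still open speak of the compounds shown alone.

Measured in a functional assay on the whole organism with Rattus norvegicus as the target (on this read-out lower numbers stand for an effect already at smaller amounts and higher numbers for an effect only at larger amounts of compound), so far:
compound 1 `CCNc1cccc(NC(=O)C(=O)OCC)c1C#N` gives 0.03 mg/kg
compound 2 `CCCNc1cccc(NC(=O)C(=O)OCC)c1C#N` gives 0.5 mg/kg
compound 3 `CCOC(=O)C(=O)Nc1cccc(N(C)CC)c1C#N` gives 0.3 mg/kg

Compound 3, at 0.3 mg/kg, belongs with the higher numbers of this small set. The comparison with the nearest value shows a 1.7-fold lower number from compound 2 to compound 3 (0.22 log units; within the scatter), so those two cannot be told apart. The distance to the lowest number is much wider, a 10-fold higher number from compound 1 to compound 3 (1.00 log units; beyond the scatter).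

The next compound is compound 4 `CCOC(=O)C(=O)Nc1cccc(N(CC)CC)c1C#N`. The change is methyl in place of hydrogen on a saturated chain carbon bound to a nitrogen on an aromatic ring, which turns ethyl(methyl)amino into diethylamino.

Within the data shown here, two measured steps bear on this. The closest in kind is a methyl added on the chain, a 17-fold higher number from compound 1 to compound 2 (1.22 log units; beyond the scatter). The other is a methyl added on the nitrogen, a 10-fold higher number from compound 1 to compound 3 (1.00 log units; beyond the scatter). Among the measured compounds shown here, both raised the number, but both start from the ethylamino of compound 1, and no step has been measured from a nitrogen that already carries two chains. A rise in the same direction seems likely, though smaller than either of these.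

In this assay the expected change is a 2.7-fold higher number from compound 3 to compound 4 (0.43 log units; beyond the scatter), towards a higher number. For compound 4 the estimate is 0.8 mg/kg, with an expected range from 0.2 mg/kg to 4 mg/kg.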

Compound 4, dose for half-maximal effect: 0.7 mg/kg
Beside the measured number, compound 4's estimate is 1.1-fold (0.06 log units) above it; measured number inside the range.
By their numbers in this assay, from the lowest: compound 1; then compounds 3, 2 and 4 (each within the scatter of the next, the first and the last beyond it).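

Lengthening a chain on this nitrogen is not a change of fixed size in this assay, and the step depends on what else the nitrogen carries: the same change on two cores in this assay, a 17-fold higher number (1.22 log units; beyond the scatter) from compound 1 to compound 2 and a 2.3-fold higher number (0.37 log units; beyond the scatter) from compound 3 to compound 4, 7.1-fold (0.85 log units) apart, beyond the scatter of two such steps. On a nitrogen that already carries two chains, the step of a 2.3-fold higher number from compound 3 to compound 4 (0.37 log units; beyond the scatter) is still beyond the scatter, whereas a 1.4-fold higher number from compound 2 to compound 4 (0.15 log units; within the scatter) stays within it, so in this assay the diethylamino and propylamino groups cannot be told apart. The widest gap in the set is a 23-fold higher number from compound 1 to compound 4 (1.37 log units; beyond the scatter), and with this result compound 1 stands apart from compounds 2, 3 and 4, since its steps to all three are printed as beyond the scatter.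

Going by these compounds, it remains open whether ethylamino marks a true optimum at this aromatic carbon, or whether a methylamino or a free amino group there would give a number lower still than compound 1 at 0.03 mg/kg. On these data alone, it is equally open whether steps of these sizes would hold if the ethyl ester of the shared core were replaced by a carboxylic acid.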